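Working notes: aromatic substituent swaps on the shared core

The compounds below may be only part of what the source reports. "The series", "measured", "known", "first", "only" and "open" are said of these compounds alone.

Measured in a functional assay on A549 cells (Homo sapiens) for inhibition, read by MTT assay, with a stated time of 72 h; a higher number here means a weaker inhibitor, a lower number a stronger inhibitor:
- compound 1 `O=[N+]([O-])c1ccc(-c2nnc(SCCCN3CCN(c4nc5ccccc5s4)CC3)o2)cc1`: 96600 nM
- compound 2 `Clc1ccc(-c2nnc(SCCCN3CCN(c4nc5ccccc5s4)CC3)o2)cc1`: 110000 nM
- compound 3 `Fc1ccc(-c2nnc(SCCCN3CCN(c4nc5ccccc5s4)CC3)o2)cc1`: 71700 nM

Compound 3 gives 71700 nM, which lies within the scatter of both compound 1 and compound 2. The three values therefore do not separate the compounds.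

The next compound is compound 4 `Oc1ccc(-c2nnc(SCCCN3CCN(c4nc5ccccc5s4)CC3)o2)cc1`, not yet measured. Its change from compound 3 is hydroxy in place of fluoro on an aromatic carbon, or 4-fluorophenyl to 4-hydroxyphenyl.

Three measured steps exchange a substituent at this same place: a 1.1-fold higher number from compound 1 to compound 2 (0.06 log units; within the scatter), a 1.3-fold lower number from compound 1 to compound 3 (0.13 log units; within the scatter) and a 1.5-fold lower number from compound 2 to compound 3 (0.19 log units; within the scatter). All three stay within the scatter, so nitro, chloro and fluoro are not told apart by these data. Among the measured compounds shown here, no measured compound carries a hydroxy group, so these steps guide the expectation only loosely, and the range has to stay wide.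

On that basis, no step beyond the scatter is expected in this assay. The estimated step is a 1.3-fold higher number from compound 3 to compound 4 (0.10 log units; within the scatter). For compound 4 the estimated value is 90000 nM, with an expected range of 35000 nM to 230000 nM.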

Compound 4, half-maximal inhibitory concentration: 62100 nM
The estimate for compound 4 lay 1.4-fold (0.16 log units) above the measured number; measured number inside the range.
By their numbers in this assay, from the lowest: compounds 4, 3, 1 and 2 (each within the scatter of the next).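

Hydroxy, on an aromatic carbon para to a large group, is the first group in this set to carry a hydrogen-bond donor, and in this assay the exchange for fluoro reads as a 1.2-fold lower number from compound 3 to compound 4 (0.06 log units; within the scatter) and stays within the scatter. The exchanges for the other two groups read the same way, with a 1.8-fold lower number from compound 2 to compound 4 (0.25 log units; within the scatter) and a 1.6-fold lower number from compound 1 to compound 4 (0.19 log units; within the scatter), so adding a hydrogen-bond donor at this position does not separate compound 4 from compound 1, compound 2 or compound 3. Nothing at hand bears on why these four values sit so close together.

Still open, as far as these compounds go, is whether any group at this position can move the number beyond the scatter, and an amine, a carboxylic acid or a methoxy group would put a different kind of substituent there to test this. Also open, from the compounds shown here alone, is whether the values in this assay respond to a change elsewhere on the shared core, such as a longer chain, since all four compounds keep that part unchanged.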